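The compounds below may be only part of what the source reports. "The series", "measured", "known", "first", "only" and "open" are said of these compounds alone.

Measured in an ADME assay on THP-1 cells (Homo sapiens) for cytotoxicity, read by MTT assay, with a stated time of 72 h; a higher number here means a weaker inhibitor, a lower number a stronger inhibitor:
- compound 1 `COc1cc(/C=C/C(=O)c2c(O)c3ccccc3[nH]c2=O)ccc1O`: 23300 nM
- compound 2 `CC(=O)N1N=C(c2c(O)c3ccccc3[nH]c2=O)CC1c1ccccc1C`: 4150 nM

Compound 1 has the higher number of the two, and the gap to compound 2 lies beyond the scatter. Going by the values given here, the two differ in more than one place, so the measured compounds offer no single-change step in this assay to use as a guide.

Compound 3 `COc1ccc(/C=C/C(=O)c2c(O)c3ccccc3[nH]c2=O)cc1OC` keeps the core of compound 1 and changes one group: methyl in place of hydrogen on an oxygen on an aromatic ring. This is methyl in place of hydrogen on an oxygen on an aromatic ring, or hydroxy to methoxy.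

Among the compounds with values here, with no measured precedent, only a small step is expected, leaning slightly towards a lower number and probably not beyond the scatter. The estimate amounts to an expected 1.7-fold lower number from compound 1 to compound 3 (0.22 log units; within the scatter). For compound 3 the estimated value is 14000 nM, with an expected range of 5000 nM to 35000 nM.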

Compound 3, half-maximal inhibitory concentration: > 50000 nM
Compound 3 gave a limit, no number; the forecaster's own chance of this, stated with the estimate: 8%; middle value at least 3.5-fold (0.55 log units) from the limit.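

In this assay, hydroxy and methoxy are not interchangeable at this place on the aromatic ring, and methyl in place of hydrogen on the oxygen gives an at least 2.1-fold higher number from compound 1 to compound 3 (0.33 log units; beyond the scatter). Compound 3 gives > 50000 nM, which is a limit of the assay and not a number. Only the direction and a minimum size can be read from this step, the first single-change comparison in the series: the limit of > 50000 nM in this assay, at which 1 of the 3 values shown sits.

On these data alone, it remains open whether an ethyl group on this oxygen, or an amine or a fluorine atom in place of the hydroxy group, would move the number in the same direction. A single step also leaves open whether this change would have the same effect on a different core, such as that of compound 2.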